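A few compounds are considered here, and "the series" means these few. Any claim that something is new, unique, unknown or untested is made for them only; others in the source may bear on it.

Compound 1 `CCCCOC(=O)NS(=O)(=O)c1sc(CC(C)C)cc1-c1ccc(Cn2ncnn2)cc1` gives 16 nM in an assay on membranes from uterus for displacement of a labelled ligand from Angiotensin type II receptor (Sus scrofa), with a stated time of 1.5 h (a lower number here means a stronger inhibitor, a higher number a weaker inhibitor), the highest of the two numbers in hand. Compound 2 `CCCCOC(=O)NS(=O)(=O)c1sc(CC(C)C)cc1-c1ccc(Cn2cnc(C(F)(F)F)c2)cc1` gives 7.3 nM in this assay, a step of a 2.2-fold lower number from compound 1 to compound 2 (0.34 log units; beyond the scatter). Compound 3 `CCCCOC(=O)NS(=O)(=O)c1sc(CC(C)C)cc1-c1ccc(C(=O)c2nccs2)cc1` differs from compound 1 by (1,3-thiazol-2-yl)carbonyl in place of (2H-tetrazol-2-yl)methyl on an aromatic carbon. Among the measured compounds shown here, the one measured step, from compound 1 to compound 2, alters the group on the same aromatic carbon and is modest, but neither the (1,3-thiazol-2-yl)carbonyl nor a carbonyl outside the ring has been tried, so it bears only loosely. For compound 3 a step of about a 1.3-fold higher number from compound 1 to compound 3 (0.10 log units; within the scatter) is expected, within or near the scatter. Compound 3 is estimated at 20 nM, range 5 nM to 80 nM.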

Compound 3, inhibition constant: 18.6 nM
Compound 3: middle estimate off by 1.1-fold (0.03 log units), on the high side, within the range that was stated.
By their numbers in this assay, from the lowest: compound 2; then compounds 1 and 3 (each within the scatter of the next).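

In this assay, the (1,3-thiazol-2-yl)carbonyl group on this aromatic carbon gives a 1.2-fold higher number from compound 1 to compound 3 (0.07 log units; within the scatter), so a carbonyl can stand in place of the saturated chain carbon, with a different five-membered aromatic ring attached, and the two compounds remain within the scatter of each other. The group bearing 4-(trifluoromethyl)-1H-imidazol-1-yl keeps the lowest number of the three, with a 2.5-fold higher number from compound 2 to compound 3 (0.41 log units; beyond the scatter). No measurement in hand accounts for either step.

Open, on these data alone, is how far the carbonyl and the ring each contribute. A methylene link to the same 1,3-thiazol-2-yl ring, or a trifluoromethyl group on that ring, would separate the two.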